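Five-membered ring replacements on the core of compound 1

The source may hold more compounds than are shown below. What is called first, only, known or untested is meant among the compounds shown, and "the series" means these compounds.

Compound 1 `c1cncc(-c2ccccc2OCC2=NCCN2)c1` stands highest of the two numbers in a functional assay for activation of Alpha-1A adrenergic receptor (Homo sapiens), read by calcium flux (a lower number here means that less compound is needed, a higher number that more compound is needed for the effect), giving 2 nM. Compound 3 `c1ccc(-c2ccoc2)c(OCC2=NCCN2)c1` gives 0.501 nM, so that a 4.0-fold lower number from compound 1 to compound 3 (0.60 log units; beyond the scatter). For compound 2 `c1ccc(-c2ccncn2)c(OCC2=NCCN2)c1` this assay reports only a limit, < 100000 nM. The steps a step that the limit leaves unreadable from compound 1 to compound 2 and a step that the limit leaves unreadable from compound 2 to compound 3 cannot be sized because of the limit of < 100000 nM in this assay, at which 1 of the 3 values shown sits.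

Compound 4 `c1ccc(-c2ccsc2)c(OCC2=NCCN2)c1` differs from compound 1 by thiophen-3-yl in place of pyridin-3-yl on an aromatic carbon. Among the compounds with values here, the one readable step that bears on this change is the earlier move to a five-membered ring with one hetero atom, a 4.0-fold lower number from compound 1 to compound 3 (0.60 log units; beyond the scatter), and a modest step in the same direction is expected here. Compound 4 is therefore estimated to give 0.8 nM, with a range from 0.25 nM to 2.5 nM. The estimated step is a 2.5-fold lower number from compound 1 to compound 4 (0.40 log units; beyond the scatter).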

Compound 4, half-maximal effective concentration: 0.251 nM
Beside the measured number, compound 4's estimate is 3.2-fold (0.50 log units) above it; low and high end bracket the measured number.
By their numbers in this assay, from the lowest: compounds 4 and 3 (each within the scatter of the next); then compound 1.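

The drop from pyridin-3-yl at this aromatic carbon now holds for two five-membered rings with one hetero atom, not just one: an 8.0-fold lower number from compound 1 to compound 4 (0.90 log units; beyond the scatter). In this assay, thiophen-3-yl and furan-3-yl are not separated, with a 2.0-fold lower number from compound 3 to compound 4 (0.30 log units; within the scatter). The steps involving compound 2 cannot be read: the limit of < 100000 nM in this assay, at which 1 of the 4 values shown sits.

Pyridin-3-yl is the only six-membered ring with a readable value, and ring size and hetero atom remain unseparated. On these data alone, how an amine or a carboxylic acid on the thiophen-3-yl ring would read in this assay stays open.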